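Nitro in Place of Triflate on a Shared Core

The source may report more compounds than this note shows. Statements on the series, on what has been measured and on what is new or still open speak of the compounds shown alone.

Of the compounds shown here, two on a shared core have been measured. Compound 1 `Cc1[nH]c2ccc(F)cc2c1C1=CCNCC1` gives 200 nM in an assay on isolated protein for displacement of a labelled ligand from 5-hydroxytryptamine receptor 1B (Rattus norvegicus) (a higher number here means a weaker inhibitor, a lower number a stronger inhibitor), and compound 2 `Cc1[nH]c2ccc(OS(=O)(=O)C(F)(F)F)cc2c1C1=CCNCC1` gives 29 nM, the lowest of the two numbers. Going by the values given here, the only step so far is a 6.9-fold lower number from compound 1 to compound 2 (0.84 log units; beyond the scatter). Compound 3 `Cc1[nH]c2ccc([N+](=O)[O-])cc2c1C1=CCNCC1` carries nitro in place of ((trifluoromethyl)sulfonyl)oxy on an aromatic carbon. That single step bears on the change only loosely, since it involved a different group at the same position, yet it shows the group there can move the number beyond the scatter. Compound 3 is therefore expected at 60 nM, between 15 nM and 250 nM, an estimated 2.1-fold higher number from compound 2 to compound 3 (0.32 log units; beyond the scatter).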

Compound 3, half-maximal inhibitory concentration: 570 nM
Estimate against measurement, compound 3: 9.5-fold (0.98 log units) below; measured number above the stated range.
By their numbers in this assay, from the lowest: compound 2; then compound 1; then compound 3.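

At this aromatic carbon, nitro in place of ((trifluoromethyl)sulfonyl)oxy gives a 20-fold higher number from compound 2 to compound 3 (1.29 log units; beyond the scatter) in this assay and is the largest change seen on the shared core so far. Nitro in place of fluoro gives a 2.9-fold higher number from compound 1 to compound 3 (0.45 log units; beyond the scatter) and so leaves compound 3 the weakest of the three. The number can therefore move in either direction from fluoro, depending on the group that enters. As far as these compounds go, whether an amine or a carboxylic acid on this carbon would lie nearer compound 2 or compound 3 remains open. No evidence is available that accounts for this order.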